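The source may report more compounds than this note shows. Statements on the series, on what has been measured and on what is new or still open speak of the compounds shown alone.

In an ADME assay on HepG2 2.2.15 cells (Homo sapiens) for cytotoxicity, read by luminescence, with a stated time of 3 days (on this read-out higher numbers stand for lower toxicity in this test and lower numbers for higher toxicity in this test), two compounds sharing one core have been measured. Compound 1 `O=C(Nc1ccc(F)c(Cl)c1)c1ccc(F)c(S(=O)(=O)N2CCCCCCC2O)c1` gives 7000 nM, while compound 2 `O=C(Nc1ccc(F)c(Cl)c1)c1ccc(F)c(S(=O)(=O)N2CCCC(O)CC2)c1` gives 29000 nM, the higher of the two numbers. Compound 3 `CC1(O)CCCN(S(=O)(=O)c2cc(C(=O)Nc3ccc(F)c(Cl)c3)ccc2F)CC1` differs from compound 2 by methyl in place of hydrogen on a saturated ring carbon. Among the measured compounds shown here, only one measured step bears on this, and only indirectly: a 4.1-fold higher number from compound 1 to compound 2 (0.62 log units; beyond the scatter). That modest step came with a change of ring size on the sulfonyl sulfur, so it gives no direct measure of adding a methyl. No step larger than that one is expected here, and most likely none beyond the scatter, with a slight lean towards a lower number. The expected change is a 1.2-fold lower number from compound 2 to compound 3 (0.08 log units; within the scatter). For compound 3 the estimated value is 24000 nM, with an expected range from 10000 nM to 60000 nM.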

Compound 3, half-maximal cytotoxic concentration: 11000 nM
Beside the measured number, compound 3's estimate is 2.2-fold (0.34 log units) above it; the range from low to high includes it.
By their numbers in this assay, from the lowest: compounds 1 and 3 (each within the scatter of the next); then compound 2.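

In this assay, among the compounds shown here, the change from 4-hydroxyazepan-1-yl to 4-hydroxy-4-methylazepan-1-yl gives the first direct reading at this ring carbon, three ring bonds from the ring nitrogen: there is a step of a 2.6-fold lower number from compound 2 to compound 3 (0.42 log units; beyond the scatter), which points towards higher toxicity in this test. The other listed step, a 1.6-fold higher number from compound 1 to compound 3 (0.20 log units; within the scatter), lies within the scatter, so compound 3 does not keep the clear separation from compound 1 that compound 2 shows. No measurement at hand accounts for the effect of this single methyl.

Going by these compounds, whether an ethyl group or a fluorine atom on the same ring carbon would give a similar step remains open. So does the outcome of replacing the hydroxyl group of compound 3 with an amine or a methoxy group.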